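A few compounds are considered here, and "the series" means these few. Any claim that something is new, unique, unknown or untested is made for them only; others in the source may bear on it.

Measured in an ADME assay on MDBK cells (Bos taurus) for cytotoxicity, read by MTT assay; a higher number here means that more compound is tolerated, a lower number that less compound is tolerated:
- compound 1 `CCCC1CCCCC1OCCCCCCN1C[C@H](O)[C@@H](O)[C@H](O)[C@H]1CO`: 150000 nM
- compound 2 `OC[C@@H]1[C@@H](O)[C@H](O)[C@@H](O)CN1CCCCCCOc1cc(F)ccc1F`: > 500000 nM (a limit)
- compound 3 `COc1ccc(OCCCCCCN2C[C@H](O)[C@@H](O)[C@H](O)[C@H]2CO)cc1`: > 500000 nM (a limit)

Compound 3 stands at the limit of > 500000 nM in this assay, at which 2 of the 3 values shown sit, so it has no exact number. Compound 4 `CCC1CCC(OCCCCCCN2C[C@H](O)[C@@H](O)[C@H](O)[C@H]2CO)CC1` puts 4-ethylcyclohexyl in place of 4-methoxyphenyl on an oxygen on a saturated carbon. Going by the values given here, two measured steps bear on this change, each replacing the non-aromatic ring of compound 1 with an aromatic one: an at least 3.3-fold higher number from compound 1 to compound 3 (0.52 log units; beyond the scatter), and an at least 3.3-fold higher number from compound 1 to compound 2 (0.52 log units; beyond the scatter). The new change runs the opposite way, from an aromatic ring to a non-aromatic one, so a lower number is expected. The expected size is modest: an at least 2.5-fold lower number from compound 3 to compound 4 (0.39 log units; beyond the scatter). The estimate for compound 4 is 200000 nM, with an expected range of 80000 nM to 500000 nM.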

Compound 4, half-maximal cytotoxic concentration: > 500000 nM
Compound 4: no number, only a limit; the forecaster's own chance of this, stated with the estimate: 25%; middle value at least 2.5-fold (0.39 log units) from the limit.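

In this assay compound 4 gives > 500000 nM, which is a limit and not a number. A non-aromatic ring on this oxygen therefore does not by itself bring a lower number: the step of an at least 3.3-fold higher number from compound 1 to compound 4 (0.52 log units; beyond the scatter) joins two non-aromatic rings, so the aromatic ring alone cannot explain the earlier steps. The steps from compound 2 and compound 3 to compound 4 cannot be read, as both ends of each are limits: the limit of > 500000 nM in this assay, at which 3 of the 4 values shown sit.

Which part of the group on compound 1 sets it apart stays open. So does how a non-aromatic ring carrying an amine or a carboxylic acid would behave.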